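The compounds below may be only part of what the source reports. "The series", "measured", "known", "first", "only" and "open" are said of these compounds alone.

Three compounds share one core and differ only in the aryl group attached to it. Compound 1 `Cc1cc(-c2ccc(C#N)cc2)cc(C)c1Nc1ccnc(Nc2ccc(C#N)cc2)n1` carries a 4-cyanophenyl there, and in an ADME assay on MT4 cells (Homo sapiens) for cytotoxicity, read by MTT assay, with a stated time of 4 days (on this read-out higher numbers stand for lower toxicity in this test and lower numbers for higher toxicity in this test), compound 1 gives 2080 nM. Compound 2 `Cc1cc(-c2ccc(F)cc2)cc(C)c1Nc1ccnc(Nc2ccc(C#N)cc2)n1` gives 4170 nM, and compound 3 `Cc1cc(-c2cccc(C#N)c2)cc(C)c1Nc1ccnc(Nc2ccc(C#N)cc2)n1` gives 920 nM. Compound 1 thus holds the second highest of the three numbers: its nearest neighbour is compound 2, with a 2.0-fold higher number from compound 1 to compound 2 (0.30 log units; within the scatter) staying within the scatter, while its furthest is compound 3, with a 2.3-fold lower number from compound 1 to compound 3 (0.35 log units; beyond the scatter) reaching beyond it.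

Compound 4 `Cc1cc(C)cc(-c2cc(C)c(Nc3ccnc(Nc4ccc(C#N)cc4)n3)c(C)c2)c1` is the next member. The change from compound 1 is 3,5-dimethylphenyl in place of 4-cyanophenyl on an aromatic carbon. For the measured compounds named here, no measured step both removes the cyano group and adds two methyl groups at once, so only indirect guidance exists. Exchanging cyano for fluoro, seen in a 2.0-fold higher number from compound 1 to compound 2 (0.30 log units; within the scatter), did little, and relocating the cyano, seen in a 2.3-fold lower number from compound 1 to compound 3 (0.35 log units; beyond the scatter), lowered the number modestly. Both steps are small, so compound 4 is expected to stay close to compound 1, with an expected step of a 1.0-fold lower number from compound 1 to compound 4 (0.02 log units; within the scatter). Compound 4 is therefore estimated at 2000 nM, within a range of 700 nM to 6000 nM.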

Compound 4, half-maximal cytotoxic concentration: 4140 nM
Compound 4: middle estimate off by 2.1-fold (0.32 log units), on the low side, and the stated range covers the measured number.
By their numbers in this assay, from the lowest: compound 3; then compounds 1, 4 and 2 (each within the scatter of the next).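

Replacing the nitrile-bearing ring with 3,5-dimethylphenyl, an aryl group of carbon only, leaves the number in this assay within the scatter, with a 2.0-fold higher number from compound 1 to compound 4 (0.30 log units; within the scatter) and a 1.0-fold lower number from compound 2 to compound 4 (0.00 log units; within the scatter), so this position accepts a group with no nitrile or fluorine and compounds 1, 2 and 4 cannot be told apart here. Compound 3 alone stands apart from the new compound, with a 4.5-fold higher number from compound 3 to compound 4 (0.65 log units; beyond the scatter), so the 3-cyanophenyl group, not the mere presence of a nitrile, is what goes with the lower number in this small set. Nothing available explains why that one group differs from the others.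

As far as these compounds go, it remains open whether a single methyl group would behave like the 3,5-dimethylphenyl pair. From the compounds shown here alone, how an amine or a carboxylic acid on this aryl ring would shift the number also remains unknown.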